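Compound 3 to compound 4: a chloro group added

This account rests on a few compounds, and the source may have more. Where it says the series, first, only, none or still open, it means among the compounds named here.

In a functional assay on NCI-H460 cells (Homo sapiens) for inhibition, read by MTT assay, with a stated time of 24 h, tested at 1 ug/mL (a higher number here means more inhibition of growth at the concentration tested, a lower number less inhibition of growth), compound 1 `O=C(CCCCC(S)CCS)NO` gives (1.17%), compound 2 `O=C(CCCCC1CCSS1)Nc1ccccc1Cl` gives (10.1%) and compound 3 `O=C(CCCCC(S)CCS)Nc1ccccc1` gives (4.3%). Compound 3 lies within the scatter of both others. Compound 4 `O=C(CCCCC(S)CCS)Nc1ccccc1Cl` carries chloro in place of hydrogen on an aromatic carbon, ortho to a large group (chloro in place of hydrogen on an aromatic carbon). Among the measured compounds shown here, no measured step tests this change. For the measured compounds named here, the only step available, (a number 3.1 percentage points higher from compound 1 to compound 3 (within the scatter)), is phenyl in place of hydroxy on an amide-type nitrogen, so it bears only indirectly. Compound 2 also carries chloro but differs elsewhere. No shift beyond the scatter is expected, and no direction can be called. The expected step is (a number 2.7 percentage points higher from compound 3 to compound 4 (within the scatter)). Compound 4 is estimated at (7%), with an expected range from (1%) to (16%).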

Compound 4, percent growth inhibition at one concentration: 8.19%
For compound 4 the middle estimate is 1.2 percentage points below the measured one, within the range that was stated.
By their numbers in this assay, from the lowest: compounds 1, 3, 4 and 2 (each within the scatter of the next).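

Chloro in place of hydrogen on an aromatic carbon, ortho to a large group, gives a number 3.9 percentage points higher from compound 3 to compound 4 (within the scatter) in this assay, the first direct reading of this change on the shared core. With the chloro kept, the group with no ring in place of the one with a five-membered non-aromatic ring gives a number 1.9 percentage points lower from compound 2 to compound 4 (within the scatter), so neither change separates from the scatter. No available evidence bears on these results. Going by these compounds, whether methoxy or trifluoromethyl on the same aromatic carbon would give a step beyond the scatter remains open.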